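This account rests on a few compounds, and the source may have more. Where it says the series, first, only, none or still open, it means among the compounds named here.

Measured compounds in a functional assay on CCRF-CEM cells (Homo sapiens), read by MTT assay, with a stated time of 72 h; a higher number here means a weaker inhibitor, a lower number a stronger inhibitor:

Compound 1 `COc1ncnc2c1c(-c1ccoc1)cn2[C@@H]1O[C@H](CO)[C@@H](O)[C@H]1O` gives 110 nM.
Compound 2 `Cc1ncnc2c1c(-c1ccoc1)cn2[C@@H]1O[C@H](CO)[C@@H](O)[C@H]1O` gives > 20000 nM, which is a limit of this assay and not a number.
Compound 3 `CSc1ncnc2c1c(-c1ccoc1)cn2[C@@H]1O[C@H](CO)[C@@H](O)[C@H]1O` gives 14200 nM.

Compound 1 stands lowest of the two numbers in this assay; its nearest neighbour is compound 3, with a 130-fold higher number from compound 1 to compound 3 (2.11 log units; beyond the scatter). Compound 2 sits at the limit of > 20000 nM in this assay, at which 1 of the 3 values shown sits, giving an at least 180-fold higher number from compound 1 to compound 2 (2.25 log units; beyond the scatter). Both of these steps exchange the methoxy group on the shared core, and both weaken inhibition strongly.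

Compound 4 `COc1ncnc2c1c(I)cn2[C@@H]1O[C@H](CO)[C@@H](O)[C@H]1O` keeps the methoxy group untouched and differs from compound 1 elsewhere: iodo in place of furan-3-yl on an aromatic carbon. Among the compounds with values here, none of the measured steps touches that position, so none bears directly on this change; the large effects seen at the methoxy group say nothing about the furan-3-yl position. With no guide among the measured steps, the expectation is held loose, centred on a modest weakening. The step expected is a 3.6-fold higher number from compound 1 to compound 4 (0.56 log units; beyond the scatter). For compound 4 the estimate in this assay is 400 nM, within a range from 60 nM to 4000 nM.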

Compound 4, half-maximal inhibitory concentration: 1150 nM
For compound 4 the middle estimate is 2.9-fold (0.46 log units) below the measured one, and the stated range covers the measured number.
By their numbers in this assay, from the lowest: compound 1; then compound 4; then compound 3. At a limit, above all of these: compound 2.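

In this assay, within the data shown here, putting iodo in place of furan-3-yl gives a 10-fold higher number from compound 1 to compound 4 (1.02 log units; beyond the scatter), so the position two ring bonds from the ring nitrogen, which the earlier compounds left unchanged, also has a large effect on the read-out. Among these compounds, the change swaps one five-membered aromatic ring for a single iodine atom and removes a hydrogen-bond acceptor, and the furan-3-yl compound is the one with the lower number. Nothing measured here explains why this step is so large.

With only these two groups shown at this position, it stays open whether the ring itself or the furan oxygen matters more, which a phenyl ring or a thiophene ring could help to separate. As far as these compounds go, it also stays open how an amine or a longer chain would behave there.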